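Notes on compound 2 and an untested cyclopropylmethyl analogue

The source may report more compounds than this note shows. Statements on the series, on what has been measured and on what is new or still open speak of the compounds shown alone.

compound 1 `Cc1cc(Nc2ccn(Cc3cccc4ccccc34)n2)n2nc(SCc3ccc(Br)cc3)nc2n1` 4310 nM
compound 2 `C#CCSc1nc2nc(C)cc(Nc3cc(-c4ccccc4)[nH]n3)n2n1` 21800 nM
compound 3 `Cc1cc(Nc2ccn(Cc3nc(C)c4ccccc4n3)n2)n2nc(SCc3ccc(Br)cc3)nc2n1` 1430 nM

In a functional assay on MCF7 cells (Homo sapiens) for inhibition, read by MTT assay, with a stated time of 72 h (a lower number here means a stronger inhibitor, a higher number a weaker inhibitor), compound 2 gives 21800 nM, the highest number of the three; compound 1 with 4310 nM sits beyond the scatter below it, and compound 3 with 1430 nM further still. For the measured compounds named here, the only measured step, a 3.0-fold lower number from compound 1 to compound 3 (0.48 log units; beyond the scatter), concerns the group on the saturated chain carbon bound to an aromatic nitrogen and says nothing about the sulfur side of the molecule.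

Compound 4 `Cc1cc(Nc2cc(-c3ccccc3)[nH]n2)n2nc(SCC3CC3)nc2n1` differs from compound 2 by cyclopropyl in place of ethynyl on a saturated chain carbon bound to a sulfur. Going by the values given here, no measured pair bears on this change, so the expectation is a step of no more than modest size in either direction, a 1.5-fold lower number from compound 2 to compound 4 (0.16 log units; within the scatter). Compound 4 is therefore estimated at 15000 nM, with a range from 5000 nM to 45000 nM.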

Compound 4, half-maximal inhibitory concentration: > 50000 nM
Compound 4: no number, only a limit (the forecaster's own chance of this, stated with the estimate: 10%); middle value at least 3.3-fold (0.52 log units) away from the limit.
By their numbers in this assay, from the lowest: compound 3; then compound 1; then compound 2. At a limit, above all of these: compound 4.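

In this assay compound 4 gives only a limit, > 50000 nM. The sulfur side of the molecule, which the earlier step did not touch, does respond to a change: cyclopropyl in place of ethynyl on a saturated chain carbon bound to a sulfur gives an at least 2.2-fold higher number from compound 2 to compound 4 (0.36 log units; beyond the scatter). This size is only a lower bound, as the read-out stops at the end of the tested range: the limit of > 50000 nM in this assay, at which 1 of the 4 values shown sits.

Open, as far as these compounds go, is how an amine or a longer straight chain in this place would read in this assay, and whether any such group would bring the number below that of compound 2.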